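Chlorobenzyl sulfanyl series: ring-position swap, whole-organism inhibition

The source may hold more compounds than are shown below. What is called first, only, known or untested is meant among the compounds shown, and "the series" means these compounds.

Measured compounds, read-out in a functional assay on the whole organism (artery, strain albino) with Rattus norvegicus as the target, with a stated time of 15 min, at a dose of 10 mg/kg by the oral route; on this read-out lower numbers stand for less inhibition and higher numbers for more inhibition at the one dose given (going by the name of the read-out):
Compound 1, `COc1ccc(C2N=C(SCc3ccccc3Cl)NC(C)=C2C(=O)Nc2ccc(Br)cc2)cc1`: compound 1 gives 3.1%
Compound 2, `COc1ccc(C2N=C(SCc3cccc(Cl)c3)NC(C)=C2C(=O)Nc2ccc(Br)cc2)cc1`: compound 2 gives 3.1%
Compound 3, `CC1=C(C(=O)Nc2ccc([N+](=O)[O-])cc2)C(c2cccc([N+](=O)[O-])c2)N=C(SCc2ccccc2Cl)N1`: compound 3 gives 2.1%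

All three measured compounds sit at the low end of this assay, and their numbers lie within the scatter of one another, so no order among them can be read. Among the compounds with values here, the single one-place change that is measured is 3-chlorophenyl in place of 2-chlorophenyl on a saturated chain carbon bound to a sulfur; the step it made is no change at the digits printed from compound 1 to compound 2 (within the scatter), that is, no movement at all in this assay.

Compound 4, `CC1=C(C(=O)Nc2ccc([N+](=O)[O-])cc2)C(c2cccc([N+](=O)[O-])c2)N=C(SCc2cccc(Cl)c2)N1`, is not yet measured. It stands to compound 3 as compound 2 stands to compound 1: the change is 3-chlorophenyl in place of 2-chlorophenyl on a saturated chain carbon bound to a sulfur. The place of the change reads the same in both pairs, so this is the same change made on a different core. How the core of compound 3 differs from the core of compound 1 is not broken down here; the two differ in more than one place.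

The expectation for compound 4 rests on compound 3 and on the measured step from compound 1 to compound 2 (no change at the digits printed from compound 1 to compound 2 (within the scatter)): the same change on the earlier core left the read-out where it was. Compound 4 is therefore expected to move from compound 3 by about a number 0.4 percentage points higher from compound 3 to compound 4 (within the scatter) in this assay. For compound 4 the estimate is 2.5%, expected to fall between 0% and 9%.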

Compound 4, a percentage reported as inhibition, in the whole organism at one dose (the size of the read-out at that dose, not a potency): 2.6%
Beside the measured number, compound 4's estimate is 0.1 percentage points below it; the range from low to high includes it.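

Replacing 2-chlorobenzyl with 3-chlorobenzyl on the core of compound 3 gives a number 0.5 percentage points higher from compound 3 to compound 4 (within the scatter) in this assay, and the two steps for this change do not differ in a way that can be read: the same change on two cores in this assay, no change at the digits printed (within the scatter) from compound 1 to compound 2 and a number 0.5 percentage points higher (within the scatter) from compound 3 to compound 4, 0.5 percentage points apart, within the scatter of two such steps
On these two cores, then, the change carries over as a swap that leaves the read-out in place, and no difference between the cores in their response to it can be claimed. Within the data shown here, this does not show that the change is without effect in general: all four numbers lie at the low end of this assay, there are only two cores and one dose, and the behaviour of the swap on a core with a higher read-out remains unknown.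

Among the groups on the sulfur, only 2-chlorobenzyl and 3-chlorobenzyl appear here, so 4-chlorobenzyl, unsubstituted benzyl and a longer alkyl chain remain open. Also open, from the compounds shown here alone, is whether an amine or a carboxylic acid in place of the bromine or the nitro groups would lift the read-out in this assay away from the low end where these compounds sit.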